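This account rests on a few compounds, and the source may have more. Where it says the series, first, only, none or still open, it means among the compounds named here.

The compounds in this series share one core and differ only in the length of the saturated chain that ends in a hydroxycarbamoyl group. In a functional assay on HCT-116 cells (Homo sapiens) for inhibition, read by sulforhodamine B assay, with a stated time of 48 h (a higher number here means a weaker inhibitor of growth, a lower number a stronger inhibitor of growth), compound 1 (`CC(C)c1cc(C(=O)N(C)c2ccc(NC(=O)CCCCCCCCC(=O)NO)cc2)c(O)cc1O`) gives 590 nM, compound 2 (`CC(C)c1cc(C(=O)N(C)c2ccc(NC(=O)CCCCCCCC(=O)NO)cc2)c(O)cc1O`) gives 1060 nM, and compound 3 (`CC(C)c1cc(C(=O)N(C)c2ccc(NC(=O)CCCCCCC(=O)NO)cc2)c(O)cc1O`) gives 830 nM. Compound 3 stands within the usual scatter of both other compounds, so these numbers do not rank it against them.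

Compound 4 (`CC(C)c1cc(C(=O)N(C)c2ccc(NC(=O)CCCCCC(=O)NO)cc2)c(O)cc1O`) takes the chain one stage further: hydroxycarbamoyl in place of (hydroxycarbamoyl)methyl on a saturated chain carbon, five bonds along the chain from a carbonyl carbon. Here, hydroxycarbamoyl stands in place of (hydroxycarbamoyl)methyl, five bonds along the chain from a carbonyl carbon. The same replacement has been measured twice further out, seven bonds along in a 1.8-fold higher number from compound 1 to compound 2 (0.25 log units; within the scatter) and six bonds along in a 1.3-fold lower number from compound 2 to compound 3 (0.11 log units; within the scatter). Making the replacement twice over gave a 1.4-fold higher number from compound 1 to compound 3 (0.15 log units; within the scatter). All three steps lie within the scatter, so no direction can be read from them, although none of them was measured at the five-bond position.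

On that evidence, no step beyond the scatter is expected in this assay, and the estimated step is a 1.0-fold higher number from compound 3 to compound 4 (0.01 log units; within the scatter). Compound 4 is estimated at 850 nM, with an expected range from 450 nM to 1600 nM.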

Compound 4, concentration for 50% growth inhibition: 3780 nM
Estimate against measurement, compound 4: 4.4-fold (0.65 log units) below, outside the stated range (above it).
By their numbers in this assay, from the lowest: compounds 1, 3 and 2 (each within the scatter of the next); then compound 4.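

In this assay, hydroxycarbamoyl in place of (hydroxycarbamoyl)methyl, five bonds along the chain from a carbonyl carbon, gives a 4.6-fold higher number from compound 3 to compound 4 (0.66 log units; beyond the scatter), the first single shortening in this series to reach beyond the scatter. The loss of growth inhibition also holds against the two longer chains, with a 3.6-fold higher number from compound 2 to compound 4 (0.55 log units; beyond the scatter) and a 6.4-fold higher number from compound 1 to compound 4 (0.81 log units; beyond the scatter), so the shortest chain of the four gives the weakest inhibitor of growth, while compounds 1, 2 and 3 remain unranked among themselves. This suggests that chain length begins to matter at this position, but the evidence does not establish that the same replacement truly has a larger effect here than further out along the chain: the same change on two cores in this assay, a 1.8-fold higher number (0.25 log units; within the scatter) from compound 1 to compound 2 and a 4.6-fold higher number (0.66 log units; beyond the scatter) from compound 3 to compound 4, 2.5-fold (0.40 log units) apart, within the scatter of two such steps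

The compounds shown leave open whether a chain shorter than that of compound 4 would weaken growth inhibition further, and whether a chain longer than that of compound 1 would preserve it. They also leave open how a carboxylic acid in place of the hydroxycarbamoyl group at the chain end would behave, and they do not explain why the loss appears at this chain length.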